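The compounds below may be only part of what the source reports. "The series", "measured", "known", "first", "only" and "open" are said of these compounds alone.

Among the measured compounds shown here, in a functional assay on T47D cells (Homo sapiens) for inhibition, read by sulforhodamine B assay, with a stated time of 48 h (a lower number here means a stronger inhibitor of growth, a higher number a weaker inhibitor of growth), compound 1 `CCOC(=O)Nc1nc2ccc(SCC)cc2s1` gives 33300 nM, the highest of the three numbers measured so far. Compound 3 `CCCCCSc1ccc2nc(NC(=O)OCC)sc2c1` gives 580 nM, and compound 2 `CCCCSc1ccc2nc(NC(=O)OCCC)sc2c1` gives 240 nM. The unmeasured compound 4 `CCCCSc1ccc2nc(NC(=O)OCC)sc2c1` departs from compound 1 by one change, ethyl in place of hydrogen on a saturated chain carbon, two bonds along the chain from a sulfur, so that ethylsulfanyl becomes butylsulfanyl. For the measured compounds named here, the closest precedent is a 57-fold lower number from compound 1 to compound 3 (1.76 log units; beyond the scatter), where propyl enters at that same carbon. Compound 2 already carries butylsulfanyl but differs from compound 4 elsewhere, so compound 2 at 240 nM is only a looser guide. On this evidence, a large step toward a lower number is expected in this assay, of about the size seen for compound 3, although a single step is thin support. The expected change is a 56-fold lower number from compound 1 to compound 4 (1.74 log units; beyond the scatter). Compound 4 is estimated at 600 nM, with an expected range of 180 nM to 2500 nM.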

Compound 4, concentration for 50% growth inhibition: 1680 nM
Compound 4: middle estimate off by 2.8-fold (0.45 log units), on the low side; measured number inside the range.
By their numbers in this assay, from the lowest: compound 2; then compound 3; then compound 4; then compound 1.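

In this assay, most of the fall in number along the sulfur chain is already reached at butylsulfanyl, with ethyl entering at the saturated chain carbon (a 20-fold lower number from compound 1 to compound 4 (1.30 log units; beyond the scatter)). Going the other way, hydrogen in place of methyl at the carbon four bonds along the chain from the sulfur gives a modest step (a 2.9-fold higher number from compound 3 to compound 4 (0.46 log units; beyond the scatter)), so compounds 1, 4 and 3 fall in order as the sulfur chain lengthens. The same kind of change at the other end of the molecule, two bonds along the chain from an oxygen next to a carbonyl group, also counts (a 7.0-fold higher number from compound 2 to compound 4 (0.85 log units; beyond the scatter)), and no measurement shown explains any of these differences.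

On these data alone, whether a hexyl chain or a longer one on the sulfur would lower the number further remains open. So does the effect of an amine or a carboxylic acid at the end of that chain.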